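Trimming a Methoxy to a Hydroxy: Expected Outcome

The source may hold more compounds than are shown below. What is called first, only, known or untested is meant among the compounds shown, and "the series" means these compounds.

Compound 1, `COc1cc(Cl)cc(-c2nn(-c3cccc(NC(=O)Nc4cccc(C(F)(F)F)c4)c3)cc2-c2ccncc2)c1`, was tested in a functional assay on CCRF-CEM cells (Homo sapiens) for inhibition, read by sulforhodamine B assay, with a stated time of 48 h, tested at 0.1 uM (a lower number here means a stronger effect, a higher number a weaker effect of the compound at the concentration tested), where compound 1 gives 97%. Compound 2, `COc1cc(Cl)cc(-c2nn(-c3cccc(NC(=O)Nc4ccc(Cl)c(C(F)(F)F)c4)c3)cc2-c2ccncc2)c1`, adds a chloro in place of hydrogen on an aromatic carbon; in this assay compound 2 gives 97%, and the step of no change at the digits printed from compound 1 to compound 2 (within the scatter). On the numbers shown, compound 2 stands level with compound 1, and both values sit high, meaning a weak effect at the concentration tested.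

Compound 3, `O=C(Nc1cccc(-n2cc(-c3ccncc3)c(-c3cc(O)cc(Cl)c3)n2)c1)Nc1ccc(Cl)c(C(F)(F)F)c1`, has not yet been measured. It differs from compound 2 in one place: hydrogen in place of methyl on an oxygen on an aromatic ring. Cut one bond further out, the change reads methoxy to hydroxy, turning the 3-chloro-5-methoxyphenyl into a 3-chloro-5-hydroxyphenyl.

For the measured compounds named here, only one measured step exists, and it concerns a different part of the molecule, so nothing measured bears directly on the oxygen. With both measured values already high, the most reasonable expectation is a step of a number 2 percentage points lower from compound 2 to compound 3 (within the scatter), none beyond the scatter. For compound 3 the estimated value in this assay is 95%, expected to fall between 82% and 105%.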

Compound 3, a percentage reported as activity, at one concentration (the size of the read-out at that concentration, not a potency): 95%
Compound 3: the middle estimate sits on the measured number at the digits printed; the range from low to high includes it.
By their numbers in this assay, from the lowest: compounds 3, 1 and 2 (each within the scatter of the next).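

Replacing the methoxy with a hydroxy on the 3-chloro-5-methoxyphenyl gives a number 2 percentage points lower from compound 2 to compound 3 (within the scatter) in this assay. For the compounds shown here, this is the first reading at this oxygen, as the earlier step concerned a chloro elsewhere in the molecule, and it shows that the methyl on the oxygen can be swapped for hydrogen without the read-out moving beyond the scatter, at this one concentration. With compound 3 at 95% in this assay, the value stays high, so the hydroxy compound, like the two methoxy compounds, shows only a weak effect here, and no separate measurement is available to help interpret this result.

All three compounds sit at the weak end of the read-out. The compounds shown do not reveal whether methoxy and hydroxy would still read alike under conditions where the effect is stronger. Going by these compounds alone, also open is whether a larger ether such as ethoxy, or an amine in place of the hydroxy, would shift the value beyond the scatter in this assay, since the only groups seen on this ring carbon so far are methoxy and hydroxy.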